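A few compounds are considered here, and "the series" means these few. Any claim that something is new, unique, unknown or untested is made for them only; others in the source may bear on it.

Measured so far in a functional assay on the whole organism (strain Wistar) for inhibition, with Rattus norvegicus as the target, read by paw edema, with stated times of 30 min and 3 h, at a dose of 20 mg/kg; on this read-out higher numbers stand for more inhibition at the one dose given (going by the name of the read-out) and lower numbers for less inhibition:

compound 1 `CCOC(=O)C1=C(C)NC(C)=C(C(=O)OCC)C1c1ccc(OCC(=O)Nc2c(C)cccc2C)cc1`: 53.9%
compound 2 `CCOC(=O)C1=C(C)NC(C)=C(C(=O)OCC)C1c1ccc(OCC(=O)Nc2ccc(C)cc2)cc1`: 61.1%

Compound 2 and compound 1 differ only at the group on the amide-type nitrogen, and the step of a number 7.2 percentage points higher from compound 1 to compound 2 (within the scatter) lies within the scatter, so on the numbers shown compound 2 sits together with compound 1 rather than apart from it; nothing in the pair separates the two.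

Compound 3 `CCOC(=O)C1=C(C)NC(C)=C(C(=O)OCC)C1c1ccc(OCC(=O)Nc2nc3ccccc3s2)cc1` arises from compound 2 by the change (1,3-benzothiazol-2-yl in place of 4-methylphenyl on an amide-type nitrogen).

Within the data shown here, the only measured step at this position is a number 7.2 percentage points higher from compound 1 to compound 2 (within the scatter), an exchange of one six-membered carbon-only ring for another on that nitrogen, and it stayed within the scatter. Among the measured compounds shown here, no measured step covers the entry of a 1,3-benzothiazol-2-yl group, or of any group with hetero atoms or hydrogen-bond acceptors, at this nitrogen, so the expectation for this assay rests on that one step alone. The step of a number 4.1 percentage points lower from compound 2 to compound 3 (within the scatter) is therefore expected to be no larger than the scatter, in no preferred direction. For compound 3 in this assay the estimate is 57%, with a range from 40% to 74%.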

Compound 3, a percentage reported as inhibition, in the whole organism at one dose (the size of the read-out at that dose, not a potency): 65.9%
Beside the measured number, compound 3's estimate is 8.9 percentage points below it, and the stated range covers the measured number.
By their numbers in this assay, from the lowest: compounds 1, 2 and 3 (each within the scatter of the next, the first and the last beyond it).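

In this assay, among these compounds, the first group with hetero atoms and hydrogen-bond acceptors on the amide-type nitrogen, 1,3-benzothiazol-2-yl, keeps compound 3 level with compound 2, as a number 4.8 percentage points higher from compound 2 to compound 3 (within the scatter) shows, so the place accepts a fused ring system of this kind without a loss in this read-out. Among the compounds shown here, the same group also gives the first step at this position that clears the scatter, a number 12 percentage points higher from compound 1 to compound 3 (beyond the scatter), although the step is modest and separates only the two ends of the row, with compound 2 within the scatter of both compound 1 and compound 3. Nothing available accounts for this difference between compound 1 and compound 3, and the data offer no measured property of either group that would explain it.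

Going by these compounds, all three compounds carry an aromatic ring on this nitrogen, so the reading for a cyclohexyl group, a pyridin-2-yl ring or a longer alkyl chain there remains open. Also open, on these data alone, is how the series would read with a carboxylic acid in place of the ethyl esters on the shared core, or at doses other than the single one given.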